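Second methoxy on the aryl ring: cytotoxicity working notes

The source may hold more compounds than are shown below. What is called first, only, known or untested is meant among the compounds shown, and "the series" means these compounds.

Compound 2 `COc1cc(-n2c(-c3cccc(O)c3)cccc2=O)cc(OC)c1OC` and compound 1 `COc1ccc(-c2cccc(=O)n2-c2cc(OC)c(OC)c(OC)c2)cc1O` share one core; compound 3 `COc1ccc(-n2c(-c3cc(OC)c(OC)c(OC)c3)cccc2=O)cc1` and compound 4 `COc1ccc(-n2c(-c3cc(OC)c(OC)c(OC)c3)cccc2=O)cc1OC` share another, and the difference between the two cores is not broken down here. In a functional assay on HepG2 cells (Homo sapiens) for cytotoxicity, read by spectrophotometry, with a stated time of 72 h (on this read-out lower numbers stand for stronger inhibition and higher numbers for weaker inhibition), compound 2 gives 34 nM. Compound 1 reaches a limit rather than a number, < 10 nM (the limit of < 10 nM in this assay, at which 1 of the 3 values shown sits). The change methoxy in place of hydrogen on an aromatic carbon produced an at least 3.4-fold lower number from compound 2 to compound 1 (0.53 log units; beyond the scatter). In this assay compound 3 gives 5740 nM. The change methoxy in place of hydrogen on an aromatic carbon is the same kind of change, but here the entering methoxy sits ortho to a methoxy group and meta to a large group, whereas in compound 1 it sits ortho to a hydroxy group and para to a large group. In this assay a step of a 3.8-fold lower number from compound 3 to compound 4 (0.58 log units; beyond the scatter) is expected, resting on an at least 3.4-fold lower number from compound 2 to compound 1 (0.53 log units; beyond the scatter) and tempered by the different surroundings. Compound 4 is estimated at 1500 nM, between 300 nM and 6000 nM.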

Compound 4, half-maximal inhibitory concentration: 4870 nM
The estimate for compound 4 lay 3.2-fold (0.51 log units) below the measured number; the range from low to high includes it.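

In this assay the entry of methoxy gives a 1.2-fold lower number from compound 3 to compound 4 (0.07 log units; within the scatter), so on this core the change leaves the number within the scatter. The same change does not carry over at the same size from one core to the other: the same change on two cores in this assay, an at least 3.4-fold lower number (0.53 log units; beyond the scatter) from compound 2 to compound 1 and a 1.2-fold lower number (0.07 log units; within the scatter) from compound 3 to compound 4, at least 2.8-fold (0.46 log units) apart, beyond the scatter of two such steps. Compound 1 gives < 10 nM, which is a limit and not a number, and the two pairs differ both in core and in the surroundings of the entering methoxy, so they do not show which of these sets the gap.

Open, from the compounds shown here alone, is whether an amine, a carboxylic acid or a longer chain at the place where methoxy enters in compound 4 would move the number. Also open, going by these compounds, is whether the gap between the two steps holds in further pairs on these two cores.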